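A Nonyl Chain Added to a Phosphate Ester

The source may hold more compounds than are shown below. What is called first, only, known or untested is meant among the compounds shown, and "the series" means these compounds.

compound 1: `CCOC(=O)C[n+]1cccc2cc(O)ccc21` — > 200000 nM
compound 2: `O=C(O[C@H]1C[C@H](n2cc(F)c(=O)[nH]c2=O)O[C@@H]1COP(=O)(O)Oc1ccccc1)c1ccccc1` — 810 nM

In a functional assay on T98G cells (Homo sapiens) for cytotoxicity, read by MTT assay, with a stated time of 48 h (a lower number here means a stronger inhibitor, a higher number a weaker inhibitor), compound 1 reaches only a limit, > 200000 nM, which is not a number but the edge of what the test reports. Going by the values given here, compound 2 gives 810 nM and is thus the only compound with a real number here; nothing else measured stands beside it for comparison. Compound 3 `CCCCCCCCCc1ccc(OP(=O)(O)OC[C@H]2O[C@@H](n3cc(F)c(=O)[nH]c3=O)C[C@@H]2OC(=O)c2ccccc2)cc1` is built from compound 2 by one change: nonyl in place of hydrogen on an aromatic carbon. Among the compounds with values here, no measured pair shows how such a change behaves in this setting, so any expectation rests on compound 2 alone. The step from compound 2 to compound 3 is expected to be a 1.6-fold lower number from compound 2 to compound 3 (0.21 log units; within the scatter), a modest shift toward a lower number that may well stay within the ordinary scatter. Compound 3 is therefore estimated at 500 nM, with a likely range from 150 nM to 2000 nM.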

Compound 3, half-maximal inhibitory concentration: 6740 nM
Beside the measured number, compound 3's estimate is 13-fold (1.13 log units) below it, outside the stated range (above it).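

In this assay, nonyl in place of hydrogen on the aromatic carbon para to a large group gives an 8.3-fold higher number from compound 2 to compound 3 (0.92 log units; beyond the scatter), a change beyond the usual scatter. A higher number here means a weaker inhibitor, so this position is not indifferent to what it carries, and this long chain weakens the compound rather than strengthening it. Even so, compound 3 still gives a real number and not a limit, so the effect of the chain can be sized.

One pair cannot show whether any group at this carbon would weaken the compound or only a chain of this length, and a methyl group, a butyl chain or an amine in the same place would help separate those cases. Nothing measured here gives a reason for the rise.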